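From 3-methylphenyl to 3-ethylphenyl in an antiproliferative series

This account rests on a few compounds, and the source may have more. Where it says the series, first, only, none or still open, it means among the compounds named here.

Compound 2 (`Cc1cccc(NS(=O)(=O)c2ccc(N3CCNC3=O)cc2)c1`) gives 200 nM in a functional assay on K562 cells (Homo sapiens) for antiproliferative activity, read by sulforhodamine B assay, with a stated time of 48 h (a lower number here means a stronger inhibitor, a higher number a weaker inhibitor), and so stands within the usual scatter of compound 1 (`O=C1NCCN1c1ccc(S(=O)(=O)Nc2ccc3[nH]ccc3c2)cc1`), which gives 340 nM there. Compound 3 (`CCc1cccc(NS(=O)(=O)c2ccc(N3CCNC3=O)cc2)c1`) differs from compound 2 by one change (methyl in place of hydrogen on a saturated chain carbon bound to an aromatic carbon), methyl in place of hydrogen on a saturated chain carbon bound to an aromatic carbon, which turns 3-methylphenyl into 3-ethylphenyl. No measured step among these compounds speaks to this change. No shift beyond the scatter is expected in this assay for it. The estimated step of a 1.1-fold lower number from compound 2 to compound 3 (0.05 log units; within the scatter) is expected to stay within that scatter. For compound 3 the expected value is 180 nM (range 70 nM to 450 nM).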

Compound 3, half-maximal inhibitory concentration: 230 nM
Compound 3: middle estimate off by 1.3-fold (0.11 log units), on the low side; measured number inside the range.
By their numbers in this assay, from the lowest: compounds 2, 3 and 1 (each within the scatter of the next).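

Methyl in place of hydrogen on a saturated chain carbon bound to an aromatic carbon gives a 1.2-fold higher number from compound 2 to compound 3 (0.06 log units; within the scatter) in this assay, so 3-ethylphenyl and 3-methylphenyl cannot be told apart in this assay. Within the data shown here, this is the first measured step at this position, as the earlier compounds offered no single-change comparison. Nothing at hand accounts for this result. On these data alone, whether a longer chain such as propyl would also stay within the scatter remains open. So does the effect of an amine or a carboxylic acid at this place.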